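From phenyl to 2-carboxyethyl on a shared core

The source may hold more compounds than are shown below. What is called first, only, known or untested is meant among the compounds shown, and "the series" means these compounds.

Of the compounds shown here, two with a shared core have been measured so far. In a functional assay on FM3A cells (Mus musculus) for cytotoxicity (on this read-out higher numbers stand for an effect only at larger amounts of compound and lower numbers for an effect already at smaller amounts), compound 1 (`C=C(C)COOC1(OOCC(=C)C)CCCCCCCCCCC1`) gives 38000 nM and compound 2 (`COOC1(OOCCCc2ccccc2)CCCCCCCCCCC1`) gives 34000 nM. These two numbers lie within the usual scatter of each other, so compound 2 stands level with compound 1 even though their side groups differ. Compound 3 (`COOC1(OOCCCCCC(=O)O)CCCCCCCCCCC1`) has 2-carboxyethyl in place of the phenyl of compound 2, on a saturated chain carbon, three bonds along the chain from an oxygen (2-carboxyethyl in place of phenyl on a saturated chain carbon, three bonds along the chain from an oxygen). Among the measured compounds shown here, no measured pair shows this kind of exchange, so the expectation rests on little evidence. A modest move towards a higher number in this assay is expected, the estimated step being a 1.8-fold higher number from compound 2 to compound 3 (0.25 log units; within the scatter). For compound 3 the estimated value is 60000 nM, with an expected range of 20000 nM to 180000 nM.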

Compound 3, half-maximal effective concentration: 14000 nM
Estimate against measurement, compound 3: 4.3-fold (0.63 log units) above, and the stated range ends above it.
By their numbers in this assay, from the lowest: compound 3; then compounds 2 and 1 (each within the scatter of the next).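

In this assay, 2-carboxyethyl in place of phenyl on a saturated chain carbon, three bonds along the chain from an oxygen, gives a 2.4-fold lower number from compound 2 to compound 3 (0.39 log units; beyond the scatter) and so moves the number beyond the scatter. Among the compounds shown here, the earlier pair stood level, so this is the first step here showing that a change at this place can shift the read-out, and it goes towards a lower number. The step rests on a single pair, however, in which an aromatic ring leaves and a chain with a hydrogen-bond donor and acceptor enters, and nothing measured here bears on the reason for the shift.

On these data alone, it remains open whether the carboxylic acid end or the loss of the phenyl ring carries the step. A methyl ester or an amine at the chain end, or a longer chain bearing the carboxylic acid, could help separate the two.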